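Losing the Sulfanyl Group: A Weak Compound at the Limit

The source may hold more compounds than are shown below. What is called first, only, known or untested is meant among the compounds shown, and "the series" means these compounds.

In a functional assay on MCF7 cells (Homo sapiens) for inhibition, read by MTT assay, with a stated time of 72 h (a higher number here means a weaker inhibitor, a lower number a stronger inhibitor), compound 1 `C#CCSc1nc2nc(C)cc(Nc3cc(-c4ccccc4)[nH]n3)n2n1` gives 21800 nM.

Compound 2 `Cc1cc(Nc2cc(-c3ccccc3)[nH]n2)n2nc(SCC3CC3)nc2n1` reads > 50000 nM, which is a limit and not a number.

Compound 3 `Cc1cc(Nc2cc(-c3ccccc3)[nH]n2)n2ncnc2n1` takes the next step from compound 2, with hydrogen in place of (cyclopropylmethyl)sulfanyl on an aromatic carbon. Among the measured compounds shown here, only one measured step bears on this change, an at least 2.2-fold higher number from compound 1 to compound 2 (0.36 log units; beyond the scatter). That step altered only the end of the sulfur-bound substituent, so it shows that this substituent can shift the reading, but not what removing it entirely does. For the measured compounds named here, no measured step supports a firm direction, so no change beyond the scatter is expected, and the estimated step is an at least 1.2-fold lower number from compound 2 to compound 3 (0.09 log units; that floor lies within the scatter). A reading at the limit of this assay would also be expected. For compound 3 the estimated value is 40000 nM, with an expected range from 15000 nM to 100000 nM.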

Compound 3, half-maximal inhibitory concentration: > 50000 nM
Compound 3: a limit, no number; the forecaster's own chance of this, stated with the estimate: 55%; middle value at least 1.2-fold (0.09 log units) from the limit.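

In this assay compound 3, which keeps the shared core and carries only hydrogen on this aromatic carbon, reads > 50000 nM, a limit and not a number. Hydrogen in place of propargylsulfanyl gives an at least 2.2-fold higher number from compound 1 to compound 3 (0.36 log units; beyond the scatter), so the measurable reading of compound 1 is lost when the whole substituent goes, whereas the earlier step had changed only the end of that substituent. The step from compound 2 to compound 3 cannot be read, because both readings are limits: the limit of > 50000 nM in this assay, at which 2 of the 3 values shown sit.

The compounds shown therefore leave open how hydrogen and (cyclopropylmethyl)sulfanyl rank against each other on this carbon. They also leave open whether an amine or a longer sulfanyl chain there would give a number, and how that number would compare with compound 1 at 21800 nM.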